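Replacing the 4-methylpiperazin-1-yl group of compound 1

This account rests on a few compounds, and the source may have more. Where it says the series, first, only, none or still open, it means among the compounds named here.

Measured in a functional assay on PC-3 cells (Homo sapiens) for inhibition, read by MTT assay, with a stated time of 72 h; a higher number here means a weaker inhibitor, a lower number a stronger inhibitor
- compound 1 `CN1CCN(c2cc(C(F)(F)F)nc(SCc3ccc(C(F)(F)F)cc3)n2)CC1` gives 34700 nM
- compound 2 `FC(F)(F)c1ccc(CSc2nc(N3CCN(c4ccccc4)CC3)cc(C(F)(F)F)n2)cc1` gives 42700 nM
- compound 3 `CC(C)(C)OC(=O)N1CCN(c2cc(C(F)(F)F)nc(SCc3ccc(C(F)(F)F)cc3)n2)CC1` gives 40600 nM

Compound 1 cannot be separated from the other two, since all three values lie within the scatter of each other. Compound 4 `FC(F)(F)c1ccc(CSc2nc(Sc3ncccn3)cc(C(F)(F)F)n2)cc1` differs from compound 1 at one place: (pyrimidin-2-yl)sulfanyl in place of 4-methylpiperazin-1-yl on an aromatic carbon. For the measured compounds named here, three measured steps bear on this only loosely: a 1.2-fold higher number from compound 1 to compound 2 (0.09 log units; within the scatter), a 1.2-fold higher number from compound 1 to compound 3 (0.07 log units; within the scatter) and a 1.1-fold lower number from compound 2 to compound 3 (0.02 log units; within the scatter). Each changes only the group on an amine nitrogen in a ring, and each stays within the scatter. None replaces the whole 4-methylpiperazin-1-yl group, so the guidance is weak and no change beyond the scatter is expected in this assay, in either direction. The expected step is a 1.1-fold lower number from compound 1 to compound 4 (0.02 log units; within the scatter). The estimate for compound 4 is 33000 nM (expected range 13000 nM to 75000 nM).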

Compound 4, half-maximal inhibitory concentration: > 50000 nM
Compound 4 was reported as a limit; the forecaster's own chance of this, stated with the estimate: 15%; at least 1.5-fold (0.18 log units) between middle value and limit.
By their numbers in this assay, from the lowest: compounds 1, 3 and 2 (each within the scatter of the next). At a limit, above all of these: compound 4.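

Replacing the whole group on this aromatic carbon, rather than only the substituent on the ring amine nitrogen, takes the series to the edge of the readable range in this assay. Compound 4 is a limit, not a number: the limit of > 50000 nM in this assay, at which 1 of the 4 values shown sits. The step reads an at least 1.4-fold higher number from compound 1 to compound 4 (0.15 log units; that floor lies within the scatter), so (pyrimidin-2-yl)sulfanyl shows no gain over 4-methylpiperazin-1-yl, and a true loss can be neither claimed nor excluded.

Going by these compounds, it remains open whether a morpholine ring or a carboxylic acid on this carbon would move the number beyond the scatter.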